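This account rests on a few compounds, and the source may have more. Where it says the series, first, only, none or still open, it means among the compounds named here.

Working notes on the series. Compound 3 `CCCS(=O)(=O)Nc1ccc(F)c(C(=O)c2n[nH]c3ncc(-c4ccc(C(N)=O)cc4)cc23)c1F` gives 4% in an assay for binding affinity to dual specificity mitogen-activated protein kinase kinase 4 (Homo sapiens), read by KINOMEscan, tested at 10 nM; on this read-out lower numbers stand for a stronger effect and higher numbers for a weaker effect at the one concentration tested. On the numbers shown it stands second highest of three: its nearest neighbour is compound 2 `CCCS(=O)(=O)Nc1ccc(F)c(C(=O)c2n[nH]c3ncc(-c4ccc(C(=O)O)cc4)cc23)c1F`, which gives 0.2%, a gap within the scatter; its furthest is compound 1 `CCCS(=O)(=O)Nc1ccc(F)c(C(=O)c2n[nH]c3ncc(-c4ccc(NS(C)(=O)=O)cc4)cc23)c1F`, which gives 16%, a gap beyond the scatter. Compound 4 `CCCS(=O)(=O)Nc1ccc(F)c(C(=O)c2n[nH]c3ncc(-c4ccc(S(N)(=O)=O)cc4C)cc23)c1F` differs from compound 3 as follows: 2-methyl-4-sulfamoylphenyl in place of 4-carbamoylphenyl on an aromatic carbon. The steps bearing on this exchange at the same ring are a number 12 percentage points lower from compound 1 to compound 3 (beyond the scatter) and a number 15.8 percentage points lower from compound 1 to compound 2 (beyond the scatter), both modest and beyond the scatter; a sulfamoyl group enters where a carbamoyl group leaves, and a methyl is added. A modest rise toward the value of compound 1 is therefore expected, a number 6 percentage points higher from compound 3 to compound 4 (within the scatter), giving an estimated 10% for compound 4, expected within 2% to 30%.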

Compound 4, a percentage reported as activity, at one concentration (the size of the read-out at that concentration, not a potency): 24%
Compound 4: middle estimate off by 14 percentage points, on the low side; measured number inside the range.
By their numbers in this assay, from the lowest: compounds 2 and 3 (each within the scatter of the next); then compounds 1 and 4 (each within the scatter of the next).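

In this assay, the 2-methyl-4-sulfamoylphenyl group loses ground against both carbonyl-bearing groups: a number 20 percentage points higher from compound 3 to compound 4 (beyond the scatter) and a number 23.8 percentage points higher from compound 2 to compound 4 (beyond the scatter). Against the other sulfonyl-bearing group, the change gives a number 8 percentage points higher from compound 1 to compound 4 (within the scatter), so across these four compounds the two sulfonyl-bearing groups read higher than the two carbonyl-bearing ones. Nothing measured here accounts for this difference.

On these data alone, the sulfamoyl group and the added methyl change together, so their separate shares of the step remain open. Also open, as far as these compounds go, is how a phenyl bearing an amine or a nitrile would read at this position.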